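Exchanging the aryl group on the shared amine nitrogen

This account rests on a few compounds, and the source may have more. Where it says the series, first, only, none or still open, it means among the compounds named here.

Of the compounds shown here, three sharing one core have been measured in a functional assay on MGC-803 cells (Homo sapiens) for inhibition, read by sulforhodamine B assay; a higher number here means a weaker inhibitor, a lower number a stronger inhibitor. Compound 1 `O=C1C=C(Nc2ccc(I)cc2)C(=O)c2c1nc1n2[C@H]2OC[C@@H](O)[C@H]2OC1` gives 1400 nM. Compound 2 `Cc1ccc(NC2=CC(=O)c3nc4n(c3C2=O)[C@H]2OC[C@@H](O)[C@H]2OC4)cc1` gives 1420 nM. Compound 3 `O=C1C=C(Nc2cccc(Cl)c2)C(=O)c2c1nc1n2[C@H]2OC[C@@H](O)[C@H]2OC1` gives 1770 nM. All three numbers sit close together: the step of a 1.0-fold higher number from compound 1 to compound 2 (0.01 log units; within the scatter) is within the scatter, as are a 1.3-fold higher number from compound 1 to compound 3 (0.10 log units; within the scatter) and a 1.2-fold higher number from compound 2 to compound 3 (0.10 log units; within the scatter). Compound 3 therefore stands among the other two rather than apart from them.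

Compound 4 `COc1ccc(NC2=CC(=O)c3nc4n(c3C2=O)[C@H]2OC[C@@H](O)[C@H]2OC4)cc1` has not yet been measured. It differs from compound 3 at the amine nitrogen: 4-methoxyphenyl in place of 3-chlorophenyl on an amine nitrogen.

For the measured compounds named here, the steps that bear on this change are those that swapped one aryl group for another at the same nitrogen, namely a 1.3-fold higher number from compound 1 to compound 3 (0.10 log units; within the scatter) and a 1.2-fold higher number from compound 2 to compound 3 (0.10 log units; within the scatter), together with a 1.0-fold higher number from compound 1 to compound 2 (0.01 log units; within the scatter), which changed only the substituent on that ring. None of them moved the number beyond the scatter, so a further exchange of the aryl group is expected to leave the number where compounds 1, 2 and 3 already sit. For compound 4 the step of a 1.2-fold lower number from compound 3 to compound 4 (0.07 log units; within the scatter) is expected to stay within the scatter. Compound 4 is thus estimated at 1500 nM, within a range from 700 nM to 3200 nM.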

Compound 4, half-maximal inhibitory concentration: 1680 nM
Estimate against measurement, compound 4: 1.1-fold (0.05 log units) below; low and high end bracket the measured number.
By their numbers in this assay, from the lowest: compounds 1, 2, 4 and 3 (each within the scatter of the next).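

In this assay the 4-methoxyphenyl group brings onto the amine nitrogen an oxygen and a hydrogen-bond acceptor that 3-chlorophenyl does not have, yet the number does not move beyond the scatter (a 1.1-fold lower number from compound 3 to compound 4 (0.02 log units; within the scatter)). The same holds when methoxy stands in place of methyl (a 1.2-fold higher number from compound 2 to compound 4 (0.07 log units; within the scatter)) and in place of iodo (a 1.2-fold higher number from compound 1 to compound 4 (0.08 log units; within the scatter)), so the flat picture set by compounds 1, 2 and 3 now extends to an aryl group carrying an oxygen, and the four compounds cannot be put in any order by this read-out. No measurement at hand accounts for why these exchanges leave the number in place.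

From the compounds shown here alone, all four groups on this nitrogen are single phenyl rings with one small substituent, so it remains open whether a ring bearing a carboxylic acid or a dimethylamino group would shift the number beyond the scatter. Going by these compounds, it is equally open whether a longer alkyl chain or a morpholine in place of the aryl ring would keep the number where these compounds sit, or whether a second substituent on the ring would change it.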